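From bromo to methyl on an aromatic carbon

The compounds below may be only part of what the source reports. "The series", "measured", "known", "first", "only" and "open" are said of these compounds alone.

Values in a functional assay on cells (Neuron, Rattus norvegicus) for inhibition, read by LDH release, with a stated time of 24 h; a higher number here means a weaker inhibitor, a lower number a stronger inhibitor:
- compound 1 `CN(c1ccc(Br)cc1)c1nc(=O)c2cccnc2s1` gives 1000 nM
- compound 2 `CCN(c1ccc(OC)cc1)c1nc(=O)c2cccnc2s1` gives 2800 nM

Compound 1 has the lower number and is therefore the stronger inhibitor of the two, and the gap up to compound 2 lies beyond the usual scatter. Compound 3 `Cc1ccc(N(C)c2nc(=O)c3cccnc3s2)cc1` has methyl in place of bromo on an aromatic carbon, para to a large group (methyl in place of bromo on an aromatic carbon), and is otherwise unchanged from compound 1. Among the compounds with values here, no two measured compounds differ in one place only, so no measured step shows what this swap does. In this assay a small rise in the number is expected, meaning a slightly weaker inhibitor, and the rise may stay within the scatter. Within the data shown here, the only hint is that compound 2, which carries no bromo, gives the higher 2800 nM here. The estimated change is a 1.7-fold higher number from compound 1 to compound 3 (0.23 log units; within the scatter) and remains an expectation. Compound 3 is expected at about 1700 nM (estimated range 600 nM to 4800 nM).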

Compound 3, half-maximal inhibitory concentration: 10000 nM
For compound 3 the middle estimate is 5.9-fold (0.77 log units) below the measured one; the whole stated range lies below it.
By their numbers in this assay, from the lowest: compound 1; then compound 2; then compound 3.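

In this assay, methyl in place of bromo on an aromatic carbon, para to a large group, gives a 10-fold higher number from compound 1 to compound 3 (1.00 log units; beyond the scatter). Within the data shown here, this is the first comparison here in which only one place changes, so it shows that this position alone can move the number clearly: one heavy atom is exchanged for one heavy atom, the rest of compound 1 stays the same, and the inhibitor becomes weaker. No measurement shown here bears on what lies behind the difference between bromo and methyl.

From the compounds shown here alone, whether chloro, fluoro or an amine at this position would stay close to compound 1 or fall nearer compound 3 remains open. Compound 2 differs from both in more than one place, so it cannot settle the effect of its methoxy.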